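The source may hold more compounds than are shown below. What is called first, only, known or untested is meant among the compounds shown, and "the series" means these compounds.

Of the compounds shown here, two have so far been tested in a functional assay on ZR-75-1 cells (Homo sapiens) for cytotoxicity; on this read-out lower numbers stand for an effect already at smaller amounts and higher numbers for an effect only at larger amounts of compound. Compound 1, with the structure `CCC[C@@H](OC(C)=O)C1=C(Br)C(=C(Br)Br)OC1=O`, gives in this assay only a limit of the measurement, < 0.1 ug/mL, and not a number; on that point the evidence reads (the limit of < 0.1 ug/mL in this assay, at which 1 of the 2 values shown sits). Compound 2, with the structure `CCC[C@@H](OC(C)=O)C1=C(Br)[C@@](C)(OC)OC1=O`, gives in this assay a value of 2.4 ug/mL. Among the compounds with values here, compound 2 thus holds the only true number among the two values shown, the other value being a limit, so no step between measured compounds can be read off.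

Compound 3, with the structure `CCC[C@@H](OC(C)=O)C1=C(Br)[C@@](CI)(OC)OC1=O`, is not yet measured. It differs from compound 2 in one place: iodo in place of hydrogen on a saturated chain carbon bound to a saturated ring carbon.

Since no measured step in this assay is shown, the step from compound 2 to compound 3 is expected to stay within the usual scatter, with no clear direction; the estimated step is a 1.2-fold lower number from compound 2 to compound 3 (0.08 log units; within the scatter). Compound 3 is therefore expected to give about 2 ug/mL in this assay, within a range of 0.6 ug/mL to 6 ug/mL.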

Compound 3, concentration for half-maximal effect: 7.9 ug/mL
Estimate against measurement, compound 3: 4.0-fold (0.60 log units) below; the whole stated range lies below it.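

Methyl to iodomethyl, on a saturated chain carbon bound to a saturated ring carbon, gives the first step in this series that can be read, and in this assay it amounts to a 3.3-fold higher number from compound 2 to compound 3 (0.52 log units; beyond the scatter) and lies beyond the usual scatter. This position is therefore not indifferent to what sits on it: a single added iodine atom moves the effect to larger amounts of compound, though compound 3 still gives a measurable number. Nothing shown here explains why this one change has this effect.

As far as these compounds go, whether chloromethyl, hydroxymethyl or aminomethyl at the same place would shift the number in the same direction, or by a similar size, stays open. Within the data shown here, compound 1 gives only a limit of the measurement, so no step involving it can be read.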